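The source may report more compounds than this note shows. Statements on the series, on what has been measured and on what is new or still open speak of the compounds shown alone.

The series starts from compound 1 `C#CCN(C)Cc1cccc(NC(=O)CCCCC(=O)NO)c1`, which in a functional assay on DU-145 cells (Homo sapiens) for inhibition, read by MTT assay, with a stated time of 48 h (a higher number here means a weaker inhibitor of growth, a lower number a stronger inhibitor of growth), gives 9750 nM. Compound 2 `C#CCN(C)Cc1cccc(NC(=O)CCCCCC(=O)NO)c1` differs from compound 1 by (hydroxycarbamoyl)methyl in place of hydroxycarbamoyl on a saturated chain carbon, four bonds along the chain from a carbonyl carbon; in this assay compound 2 gives 4290 nM, so that a 2.3-fold lower number from compound 1 to compound 2 (0.36 log units; beyond the scatter). Compound 3 `C#CCN(C)Cc1ccc(NC(=O)CCCCCCC(=O)NO)cc1` rests on a different core, and the difference between the two cores is not broken down here. In this assay compound 3 gives 1510 nM, the lowest of the three numbers. Compound 4 `C#CCN(C)Cc1ccc(NC(=O)CCCCCCCC(=O)NO)cc1` has not yet been measured; it differs from compound 3 by (hydroxycarbamoyl)methyl in place of hydroxycarbamoyl on a saturated chain carbon, six bonds along the chain from a carbonyl carbon, the same kind of change as from compound 1 to compound 2, though here on a saturated chain carbon six bonds along the chain from a carbonyl carbon rather than four. For compound 4 a step of about a 2.0-fold lower number from compound 3 to compound 4 (0.30 log units; within the scatter) is expected, set beside the earlier one, because the earlier lengthening gave a 2.3-fold lower number from compound 1 to compound 2 (0.36 log units; beyond the scatter). The estimate for compound 4 is therefore 750 nM, with a range from 350 nM to 1600 nM.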

Compound 4, concentration for 50% growth inhibition: 3400 nM
Compound 4: the middle estimate sits 4.5-fold (0.66 log units) below what was measured; measured number above the stated range.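

In this assay, putting (hydroxycarbamoyl)methyl in place of hydroxycarbamoyl on the core of compound 3 gives a 2.3-fold higher number from compound 3 to compound 4 (0.35 log units; beyond the scatter), opposite in direction to the step on the core of compound 1. The change thus does not carry from one core to the other with a fixed direction: the same change on two cores in this assay, a 2.3-fold lower number (0.36 log units; beyond the scatter) from compound 1 to compound 2 and a 2.3-fold higher number (0.35 log units; beyond the scatter) from compound 3 to compound 4, 5.1-fold (0.71 log units) apart, beyond the scatter of two such steps This rests on one pair per core, and the change sits four bonds along the chain in one pair and six in the other, so it does not show whether the core or the chain position sets the direction.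

The compounds shown leave open how a longer chain would read on the core of compound 3. They also leave open whether a carboxylic acid in place of hydroxycarbamoyl would retain any growth inhibition.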